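A Carbamoyl Replaces a Vinyl on the Shared Core

A few compounds are considered here, and "the series" means these few. Any claim that something is new, unique, unknown or untested is made for them only; others in the source may bear on it.

Compound 2 `C=Cc1ccn2ncc(/C=N/N(C)S(=O)(=O)c3cc([N+](=O)[O-])ccc3C)c2c1` carries a vinyl group on an aromatic carbon of its core. In an assay on isolated protein for inhibition of phosphatidylinositol 4,5-bisphosphate 3-kinase catalytic subunit beta isoform (Homo sapiens), read by 33P incorporation, with a stated time of 60 min (on this read-out higher numbers stand for weaker inhibition and lower numbers for stronger inhibition), compound 2 gives > 1000 nM, which is a limit of the assay and not a measured number. Among the measured compounds shown here, its only neighbour among the measured compounds is compound 1 `CC(=O)Oc1ccn2ncc(/C=N/N(C)S(=O)(=O)c3cc([N+](=O)[O-])ccc3C)c2c1`, which differs in carrying an acetoxy group in place of that vinyl. In this assay compound 1 gives > 1000 nM, again a limit. The step from compound 1 to compound 2 is therefore not readable, a step that the two limits leave unreadable from compound 1 to compound 2, because the limit of > 1000 nM in this assay, at which 2 of the 2 values shown sit, leaves both ends open.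

The next compound, compound 3 `Cc1ccc([N+](=O)[O-])cc1S(=O)(=O)N(C)/N=C/c1cnn2ccc(C(N)=O)cc12`, differs from compound 2 as follows: carbamoyl in place of vinyl on an aromatic carbon. Only the one measured step bears on this change, and its size cannot be read, so the numbers shown give no direction for the new step; all that is known is that both values so far sit at the limit. Compound 3 is thus expected to stay in the same region, with an estimated step that the limit leaves unreadable from compound 2 to compound 3. The estimate for compound 3 in this assay is 3000 nM, within a range from 500 nM to 20000 nM.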

Compound 3, half-maximal inhibitory concentration: > 1000 nM
Compound 3: no number, only a limit (the forecaster's own chance of this, stated with the estimate: 65%); the middle value lies beyond the limit too.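

Among the compounds shown here, no step among compound 1, compound 2 and compound 3 can be read in this assay, because each value is a limit of the assay and not a number: the limit of > 1000 nM in this assay, at which 3 of the 3 values shown sit. The compounds shown leave open how far each lies beyond that limit, and whether acetoxy, vinyl or carbamoyl on this aromatic carbon differ at all in inhibition.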